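Swapping phenyl for furan at a readout limit

This account rests on a few compounds, and the source may have more. Where it says the series, first, only, none or still open, it means among the compounds named here.

Measured in a functional assay on K562 cells (Homo sapiens) for antiproliferative activity, read by MTT assay, with a stated time of 24 h (on this read-out lower numbers stand for stronger inhibition and higher numbers for weaker inhibition), so far:
Compound 1 `COc1ccc(C(=O)/C=C/c2cccc(F)c2)c2c1C=CC(C)(C)O2` gives > 10000 nM (a limit)
Compound 2 `COc1ccc(C(=O)/C=C/c2ccc(N(C)C)cc2)c2c1C=CC(C)(C)O2` gives 3500 nM
Compound 3 `COc1ccc(C(=O)/C=C/c2ccccc2)c2c1C=CC(C)(C)O2` gives > 10000 nM (a limit)

Compound 3 gives > 10000 nM as a limit of the assay, not a number. Compound 3 sits at the limit of > 10000 nM in this assay, at which 2 of the 3 values shown sit, and so offers no exact starting point.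

The change to compound 4 `COc1ccc(C(=O)/C=C/c2ccco2)c2c1C=CC(C)(C)O2` is furan-2-yl in place of phenyl on a double-bonded chain carbon bound to a double-bonded chain carbon and touches the same ring position of the chain end that varies across the measured compounds. For the measured compounds named here, no measured step tests a furan-2-yl group directly, so the evidence is indirect. Compound 2 is the only one of the three with a readable value, and its steps are an at least 2.8-fold lower number from compound 1 to compound 2 (0.45 log units; beyond the scatter) and an at least 2.8-fold higher number from compound 2 to compound 3 (0.45 log units; beyond the scatter). The third step is a step that the two limits leave unreadable from compound 1 to compound 3 and tells nothing about size. Compound 4 has no dimethylamino group, the group whose removal gave an at least 2.8-fold higher number from compound 2 to compound 3 (0.45 log units; beyond the scatter), so no gain of that kind is expected.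

The expected step is a step that the limit leaves unreadable from compound 3 to compound 4 in this assay, and none beyond the scatter is foreseen. For compound 4 the estimated value is 12000 nM, with an expected range of 5000 nM to 30000 nM and a limit as the likely report.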

Compound 4, half-maximal inhibitory concentration: > 10000 nM
Compound 4 was reported as a limit; the forecaster's own chance of this, stated with the estimate: 70%; the middle value does not contradict the limit.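

In this assay compound 4 gives > 10000 nM as a limit of the assay and not a number. For the compounds shown here, putting furan-2-yl, a five-membered aromatic ring with one oxygen, at this place on the chain does not bring a readable value: exchanging the 4-(dimethylamino)phenyl group for it gives an at least 2.8-fold higher number from compound 2 to compound 4 (0.45 log units; beyond the scatter) and leaves compound 2 as the only readable compound of the four. The steps from compound 1 and compound 3 to compound 4 cannot be read, so furan-2-yl cannot be ranked against phenyl or 3-fluorophenyl, and the series now clusters at one end of the scale: the limit of > 10000 nM in this assay, at which 3 of the 4 values shown sit.

From the compounds shown here alone, how far compound 1, compound 3 and compound 4 lie past that limit stays unknown, and a test at higher concentrations would be needed to separate them. Also open, going by these compounds, is whether the readable value needs dimethylamino itself or would survive with a simple amino group or a morpholine ring in its place, and whether a dimethylamino group on a furan ring would give a readable value as well.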